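Swapping Cyano for Vinyl in a Small Cytotoxicity Series

This account rests on a few compounds, and the source may have more. Where it says the series, first, only, none or still open, it means among the compounds named here.

Compound 1 is `CC1(Cc2ccccc2)OS(=O)(=O)C=C1OCc1ccccc1`; in an ADME assay on HEL cells (Homo sapiens) for cytotoxicity, with a stated time of 3 days (on this read-out lower numbers stand for higher toxicity in this test and higher numbers for lower toxicity in this test), compound 1 gives 68000 nM.
Compound 2 is `CCC1(CC)OS(=O)(=O)C=C1OCc1ccccc1`; in this assay compound 2 gives 200000 nM.
Compound 3 is `CCC1(Cc2ccccc2)OS(=O)(=O)C=C1OCC#N`; in this assay compound 3 gives > 200000 nM.

For compound 3 that figure is a limit of this assay rather than a measured number (the limit of > 200000 nM in this assay, at which 1 of the 3 values shown sits). So compound 3 is the one compound of the three for which only a limit is known, while compound 1 and compound 2 each have a number, the number for compound 2 lying higher than that for compound 1. No two of these compounds differ in only one place, so none of the differences between them can be read as a single step.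

Compound 4 is `C=CCOC1=CS(=O)(=O)OC1(CC)Cc1ccccc1`. It differs from compound 3 in one place: vinyl in place of cyano on a saturated chain carbon bound to an oxygen on an unsaturated carbon. The two groups are of the same size, and nothing measured here tells what such a swap does to cytotoxicity, so no step beyond the usual scatter is expected in either direction. Compound 4 is therefore estimated to sit near where compound 3 stands, which means an expected step of an at least 1.2-fold lower number from compound 3 to compound 4 (0.09 log units; that floor lies within the scatter), giving an estimate for compound 4 of 160000 nM, with a range from 50000 nM to 400000 nM.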

Compound 4, half-maximal cytotoxic concentration: > 200000 nM
Compound 4: no number, only a limit (the forecaster's own chance of this, stated with the estimate: 40%); middle value at least 1.2-fold (0.09 log units) away from the limit.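

In this assay compound 4 gives > 200000 nM, which is a limit of the assay and not a number. Compound 3 also has only a limit, so no step can be read between compound 3 and compound 4: the limit of > 200000 nM in this assay, at which 2 of the 4 values shown sit.

The compounds shown leave open whether vinyl in place of cyano shifts cytotoxicity at all, and in which direction.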